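From Pentyl to Pyridin-3-yl on the Benzylic Carbon

The compounds below may be only part of what the source reports. "The series", "measured", "known", "first", "only" and "open" are said of these compounds alone.

Compound 3 `CCCCCC(c1ccccc1)n1ccc2cc(/C(C)=C/C(=O)Nc3ccccc3OCCCC(=O)O)ccc21` stands second highest of the three numbers measured in an assay on Prostate gland for inhibition of steroid 5-alpha-reductase (Rattus norvegicus) (a lower number here means a stronger inhibitor, a higher number a weaker inhibitor), where compound 3 gives 25 nM. Its nearest neighbour is compound 2 `CCCCC(CC)n1ccc2cc(/C(C)=C/C(=O)Nc3ccccc3OCCCC(=O)O)ccc21`, which in this assay gives 7.1 nM; the step of a 3.5-fold higher number from compound 2 to compound 3 (0.55 log units; beyond the scatter) lies beyond the scatter. Furthest away is compound 1 `CC(C)=CCn1ccc2cc(/C(C)=C/C(=O)Nc3ccccc3OCCCC(=O)O)ccc21`, which in this assay gives 120 nM, with the step of a 4.8-fold lower number from compound 1 to compound 3 (0.68 log units; beyond the scatter) also beyond the scatter, and the larger step of a 17-fold lower number from compound 1 to compound 2 (1.23 log units; beyond the scatter) between the other two.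

Compound 4 `C/C(=C\C(=O)Nc1ccccc1OCCCC(=O)O)c1ccc2c(ccn2C(c2ccccc2)c2cccnc2)c1` differs from compound 3 by pyridin-3-yl in place of pentyl on a saturated chain carbon bound to an aromatic carbon and an aromatic nitrogen. Within the data shown here, no measured step touches this position: the two steps that change the substituent on the aromatic nitrogen, a 4.8-fold lower number from compound 1 to compound 3 (0.68 log units; beyond the scatter) and a 3.5-fold higher number from compound 2 to compound 3 (0.55 log units; beyond the scatter), replace the whole group, not a chain on the saturated carbon. They show that the present group of compound 3 sits between those of compound 1 and compound 2, and nothing more can be drawn from them for a pyridin-3-yl. Compound 4 is therefore estimated with a wide range, and a step of a 2.4-fold higher number from compound 3 to compound 4 (0.38 log units; beyond the scatter) is expected, because the alkyl-bearing compound 2 at 7.1 nM outperforms the aryl-bearing compound 3 at 25 nM. Compound 4 is expected to give about 60 nM, between 15 nM and 250 nM.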

Compound 4, half-maximal inhibitory concentration: 47 nM
The estimate for compound 4 lay 1.3-fold (0.11 log units) above the measured number; the measured number falls inside the stated range.
By their numbers in this assay, from the lowest: compound 2; then compounds 3 and 4 (each within the scatter of the next); then compound 1.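

In this assay, putting pyridin-3-yl in place of pentyl on a saturated chain carbon bound to an aromatic carbon and an aromatic nitrogen gives a 1.9-fold higher number from compound 3 to compound 4 (0.27 log units; within the scatter) and so does not move the number beyond the scatter. Among these compounds, this is the first measured change made at this carbon itself, with the phenyl of compound 3 kept in compound 4, whereas the earlier steps replaced the whole group on the aromatic nitrogen. Here the assay does not separate an open five-carbon chain with no ring and no hydrogen-bond acceptor from a six-membered aromatic ring with one hetero atom and one hydrogen-bond acceptor, and no measurement is at hand that would account for this result.

The compounds shown leave open whether the same holds for other groups at this carbon, such as pyridin-2-yl, pyridin-4-yl, a second phenyl or a shorter chain like ethyl. They also do not tell how a group carrying an amine or a carboxylic acid would read here, or whether the pyridine nitrogen itself matters at all.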